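Replacing the nitro group of compound 3

The source may report more compounds than this note shows. Statements on the series, on what has been measured and on what is new or still open speak of the compounds shown alone.

Compound 1 `O=c1[nH]c(=O)n(C[C@@H]2C[C@H](O)c3ccccc32)cc1Br` gives > 200000 nM
Compound 2 `CC1(C)[C@@H](Cn2nnc3c(N)nc(N)nc32)CC[C@@]1(C)CO` gives > 200000 nM
Compound 3 `O=c1[nH]c(=O)n([C@H]2C[C@H](O)[C@@H](CO)O2)cc1[N+](=O)[O-]` gives 130 nM

All three compounds were tested in an ADME assay on L1210/0 cells (Mus musculus) for cytotoxicity, with a stated time of 48 h; on this read-out lower numbers stand for stronger inhibition and higher numbers for weaker inhibition. The entries for compound 1 and compound 2 are limits and not numbers: the limit of > 200000 nM in this assay, at which 2 of the 3 values shown sit. Compound 3 is the only one of the three with an actual number, so its standing can be read only against that limit.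

The next compound to be tested is compound 4 `O=C(CI)NCc1cn([C@H]2C[C@H](O)[C@@H](CO)O2)c(=O)[nH]c1=O`, which carries (((iodomethyl)carbonyl)amino)methyl in place of nitro on an aromatic carbon. The rest of the structure is unchanged. Going by the values given here, none of the measured compounds differ from one another in a single place, so the data offer no direct precedent for the size of this change, and any forecast is uncertain.

With compound 3 at 130 nM as the sole numerical anchor in this assay, a clear loss of inhibition is expected, well beyond the usual scatter. The expected step is a 150-fold higher number from compound 3 to compound 4 (2.19 log units; beyond the scatter), in the direction of weaker inhibition. Compound 4 is estimated at 20000 nM, with an expected range from 2000 nM to 150000 nM.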

Compound 4, half-maximal inhibitory concentration: 107000 nM
Compound 4: middle estimate off by 5.4-fold (0.73 log units), on the low side; low and high end bracket the measured number.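

This pair is the first among the compounds shown to differ in one place, so the effect of a change on this aromatic carbon of the six-membered aromatic ring with 2 nitrogen can now be read directly. In this assay, putting (((iodomethyl)carbonyl)amino)methyl in place of nitro gives an 820-fold higher number from compound 3 to compound 4 (2.92 log units; beyond the scatter), a large step towards weaker inhibition with the rest of the structure unchanged. The read-out therefore depends strongly on the group at this position, yet compound 4 still returns an actual number and not a limit, unlike the entries that sit at the top of the range: the limit of > 200000 nM in this assay, at which 2 of the 4 values shown sit.

A single replacement cannot show which part of the entering group goes with the loss, whether the iodomethyl end, the carbonyl, the amide hydrogen or the methyl link to the ring, nor how much of the step simply reflects the departure of nitro. A smaller group on the same carbon, such as aminomethyl or a carboxylic acid, would begin to separate these possibilities.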